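Compound 4: the Same Atoms, Joined Differently

The source may report more compounds than this note shows. Statements on the series, on what has been measured and on what is new or still open speak of the compounds shown alone.

Measured so far in a functional assay on the whole organism (strain Wistar) for inhibition, with Rattus norvegicus as the target, read by paw edema, with stated times of 30 min and 2 h, at a dose of 20 mg/kg; a lower number here means less inhibition, a higher number more inhibition at the dose given (going by the name of the read-out):
- compound 1 `CCOC(=O)C1=C(C)NC(C)=C(C(=O)OCC)C1c1ccc(OCC(=O)NCc2ccccc2)cc1` gives 8.9%
- compound 2 `CCOC(=O)C1=C(C)NC(C)=C(C(=O)OCC)C1c1ccc(OCC(=O)NNC(=O)c2ccc(C)cc2)cc1` gives 46.7%
- compound 3 `CCOC(=O)C1=C(C)NC(C)=C(C(=O)OCC)C1c1ccc(OCC(=O)NNC(=O)c2sccc2Cl)cc1` gives 57.2%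

Compound 3 stands highest of the three. Its nearest neighbour is compound 2, the step being a number 10.5 percentage points higher from compound 2 to compound 3 (beyond the scatter), a modest one that is nonetheless beyond the scatter. The gap to compound 1 is far larger: a number 48.3 percentage points higher from compound 1 to compound 3 (beyond the scatter), and compound 2 sits similarly far from compound 1, at a number 37.8 percentage points higher from compound 1 to compound 2 (beyond the scatter).

Compound 4 `CCOC(=O)C1=C(C)NC(C)=C(C(=O)OCC)C1c1ccc(OCC(=O)NNC(=O)c2ccsc2Cl)cc1` differs from compound 3 only in how the same atoms are joined: 2-chlorothiophen-3-yl in place of 3-chlorothiophen-2-yl on a carbonyl carbon.

Within the data shown here, the only measured step that bears on this is the exchange of one aryl group for another on the carbonyl carbon, a number 10.5 percentage points higher from compound 2 to compound 3 (beyond the scatter), which was modest. The present change is smaller still, since nothing enters or leaves. A step within the scatter, in either direction, is therefore expected: a number 5.2 percentage points lower from compound 3 to compound 4 (within the scatter). Compound 4 is estimated at 52%, with a range from 38% to 66%.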

Compound 4, a percentage reported as inhibition, in the whole organism at one dose (the size of the read-out at that dose, not a potency): 52.8%
Estimate against measurement, compound 4: 0.8 percentage points below; measured number inside the range.
By their numbers in this assay, from the lowest: compound 1; then compounds 2, 4 and 3 (each within the scatter of the next, the first and the last beyond it).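

In this assay, moving from one chlorothiophene to its isomer on the carbonyl carbon gives a number 4.4 percentage points lower from compound 3 to compound 4 (within the scatter), so at this position this rejoining of the same atoms leaves the read-out within the scatter. The earlier separation of 3-chlorothiophen-2-yl from 4-methylphenyl, a number 10.5 percentage points higher from compound 2 to compound 3 (beyond the scatter), does not carry over to the isomer, for which the exchange gives a number 6.1 percentage points higher from compound 2 to compound 4 (within the scatter), while the distance from the benzyl amide remains large at a number 43.9 percentage points higher from compound 1 to compound 4 (beyond the scatter). Nothing at hand explains any of these steps.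

The compounds shown leave open what a thiophene ring without chlorine, or a pyridine ring, would give on this carbonyl carbon. They also leave open whether a bromine in place of the chlorine would stay within the scatter of compound 3 and compound 4.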